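The source may hold more compounds than are shown below. What is called first, only, known or untested is meant among the compounds shown, and "the series" means these compounds.

Series notes, first assay block. Compound 1 `Cc1ccc(S(=O)(=O)N2C=CNC(=O)[C@H]2CC(=O)N[C@@H]2CCCc3cc(CN(C)C)ccc32)cc1` gives 0.21 nM in an in vitro functional assay on cells for antagonist activity at B1 bradykinin receptor (Homo sapiens), read by luminescence and calcium flux, with a stated time of 2 h (a lower number here means a stronger inhibitor, a higher number a weaker inhibitor), compound 3 `COc1ccc2c(c1)C(NC(=O)C[C@@H]1C(=O)NC=CN1S(=O)(=O)c1ccc(C)cc1)CCC2` gives 178 nM, and compound 2 `Cc1ccc(S(=O)(=O)N2C=CNC(=O)[C@H]2CC(=O)N[C@H](C)c2ccccc2)cc1` gives 836 nM, the highest of the three numbers, with compound 3 nearest and compound 1 furthest away, both gaps beyond the scatter. Compound 4 `Cc1ccc(S(=O)(=O)N2C=CNC(=O)[C@H]2CC(=O)NC2CCCCC2C)cc1` differs from compound 2 by 2-methylcyclohexyl in place of 1-phenylethyl on an amide-type nitrogen. Among the compounds with values here, no measured pair differs in one place, so there is no step to lean on; the only anchor is compound 2 at 836 nM. The expected step is a 1.8-fold higher number from compound 2 to compound 4 (0.25 log units; within the scatter), modest and if anything toward a higher number, not confidently beyond the scatter. Compound 4 is therefore estimated at 1500 nM, in the range 300 nM to 8000 nM.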

Compound 4, half-maximal inhibitory concentration: 25.9 nM
Compound 4: middle estimate off by 58-fold (1.76 log units), on the high side, and the stated range ends above it.
By their numbers in this assay, from the lowest: compound 1; then compound 4; then compound 3; then compound 2.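

In this assay, 2-methylcyclohexyl in place of 1-phenylethyl on an amide-type nitrogen gives a 32-fold lower number from compound 2 to compound 4 (1.51 log units; beyond the scatter). The six-membered aromatic ring of carbon only is therefore not required at this position, since a six-membered non-aromatic ring of carbon only gives the lower number. No data shown bear on the reason for this step.

On these data alone, it remains open whether the gain depends on the ring, the methyl group, or both, which plain cyclohexyl would help separate. Also open, as far as these compounds go, is how an amine on the cyclohexyl ring would read here.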